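Chloro-fluoro phenyl swap repeated on a second core

The source may report more compounds than this note shows. Statements on the series, on what has been measured and on what is new or still open speak of the compounds shown alone.

Compound 1 `O=C(O)/C=C/c1ccc(/C(=C(\c2ccccc2)C2CCC2)c2ccc3scnc3c2)cc1` and compound 3 `O=C(O)/C=C/c1ccc(/C(=C(\c2ccccc2)C2CCC2)c2ccc(-c3cncs3)cc2)cc1` share everything except the core, which differs as 4-(1,3-thiazol-5-yl)phenyl in place of 1,3-benzothiazol-5-yl on a double-bonded chain carbon bound to an aromatic carbon and a double-bonded chain carbon. In a functional assay on MCF7 cells (Homo sapiens) for antiproliferative activity, read by CellTiter-Glo, with a stated time of 5 days (on this read-out lower numbers stand for stronger inhibition and higher numbers for weaker inhibition), compound 1 gives 16 nM, and compound 3 gives 9.2 nM; a 1.7-fold lower number from compound 1 to compound 3 (0.24 log units; within the scatter), so the two cores are not separated here. Compound 2 `O=C(O)/C=C/c1ccc(/C(=C(\c2ccc(F)cc2Cl)C2CCC2)c2ccc3scnc3c2)cc1` carries 2-chloro-4-fluorophenyl in place of phenyl on a double-bonded chain carbon bound to a double-bonded chain carbon and a saturated ring carbon on the core of compound 1; in this assay compound 2 gives 3 nM, and a 5.3-fold lower number from compound 1 to compound 2 (0.73 log units; beyond the scatter). Compound 4 `O=C(O)/C=C/c1ccc(/C(=C(\c2ccc(F)cc2Cl)C2CCC2)c2ccc(-c3cncs3)cc2)cc1`, not yet measured, applies the same change to the core of compound 3: 2-chloro-4-fluorophenyl in place of phenyl on a double-bonded chain carbon bound to a double-bonded chain carbon and a saturated ring carbon, with the place worded identically in both cases. A step of about a 4.6-fold lower number from compound 3 to compound 4 (0.66 log units; beyond the scatter) is expected for compound 4, because a 5.3-fold lower number from compound 1 to compound 2 (0.73 log units; beyond the scatter) was seen on the other core and the two cores sit within the scatter of each other. Compound 4 is therefore estimated at 2 nM, with a likely range of 0.8 nM to 6 nM.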

Compound 4, half-maximal inhibitory concentration: 4.2 nM
Compound 4: middle estimate off by 2.1-fold (0.32 log units), on the low side, within the range that was stated.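

In this assay the change to 2-chloro-4-fluorophenyl lowers the number on the second core as well, with a 2.2-fold lower number from compound 3 to compound 4 (0.34 log units; beyond the scatter), and the steps on the two cores are not separated: the same change on two cores in this assay, a 5.3-fold lower number (0.73 log units; beyond the scatter) from compound 1 to compound 2 and a 2.2-fold lower number (0.34 log units; beyond the scatter) from compound 3 to compound 4, 2.4-fold (0.39 log units) apart, within the scatter of two such steps
With 2-chloro-4-fluorophenyl in place, the swap of cores gives a 1.4-fold higher number from compound 2 to compound 4 (0.15 log units; within the scatter), which is not separated from the same swap with phenyl: the same change on two cores in this assay, a 1.7-fold lower number (0.24 log units; within the scatter) from compound 1 to compound 3 and a 1.4-fold higher number (0.15 log units; within the scatter) from compound 2 to compound 4, 2.4-fold (0.39 log units) apart, within the scatter of two such steps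
This supports carrying the change between these two cores only; it does not show that the step holds on any other core, nor which of the two halogens accounts for it.

Still open, on these data alone, is whether 2-chlorophenyl or 4-fluorophenyl alone gives such a step. Also open, as far as these compounds go, is whether a nitrile or trifluoromethyl on that phenyl carries over between the cores in the same way.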